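Swapping pyridin-3-yl for cyclohexyl on compound 2

The source may report more compounds than this note shows. Statements on the series, on what has been measured and on what is new or still open speak of the compounds shown alone.

Measured so far in a physicochemical assay for lipophilicity, read by HPLC, measured as chromatographic lipophilicity, at pH 7.4; on this read-out lower numbers stand for lower lipophilicity and higher numbers for higher lipophilicity
- compound 1 `CC(C)(C)C(=O)N1CCNCC1c1ccccc1` gives 2.5
- compound 2 `O=C(c1cccnc1)N1CCC(C(=O)N2N=CCC2c2ccccc2)CC1` gives 2.6
- compound 3 `O=C(C1CCCCC1)N1N=CCC1c1ccccc1` gives 5.9

Compound 2 at 2.6 cannot be told apart from compound 1 at 2.5 in this assay and both sit well beyond the scatter under compound 3. Among the measured compounds shown here, the next structure is compound 4 `O=C(C1CCCCC1)N1CCC(C(=O)N2N=CCC2c2ccccc2)CC1` with cyclohexyl in place of pyridin-3-yl on a carbonyl carbon and no measured pair shows this swap directly. The nearest clue is compound 3, which also holds cyclohexyl on a carbonyl carbon and gives 5.9 here. The estimated step of a number 1.60 log units higher from compound 2 to compound 4 (beyond the scatter) is an expected rise beyond the scatter. The estimate for compound 4 is 4.2 with a range from 3.4 to 5 expected.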

Compound 4, distribution coefficient: 5.4
Compound 4: the middle estimate sits 1.20 log units below what was measured; measured number above the stated range.
By their numbers in this assay, from the lowest: compounds 1 and 2 (each within the scatter of the next); then compound 4; then compound 3.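

In this assay, among the compounds shown here, cyclohexyl in place of pyridin-3-yl on a carbonyl carbon gives a large change, a number 2.80 log units higher from compound 2 to compound 4 (beyond the scatter), and this is the first direct reading of this swap. The two rings hold the same number of heavy atoms, and only pyridin-3-yl carries a hydrogen-bond acceptor, so this position clearly responds to which ring sits there. Nothing available explains the size of the step.

On these data alone, whether the ring nitrogen or the aromatic ring matters more stays open, and phenyl on the same carbonyl carbon would help separate the two. As far as these compounds go, how an amine or a carboxylic acid would read at this place also remains open.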